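Taking the Methyl Away from Compound 2

The source may report more compounds than this note shows. Statements on the series, on what has been measured and on what is new or still open speak of the compounds shown alone.

Of the compounds shown here, two have been measured so far in a functional assay on OVCAR-3 cells (Homo sapiens); a higher number here means a weaker inhibitor of growth, a lower number a stronger inhibitor of growth. In this test, compound 1 (`COc1cccc(-c2cc(O)c3cc(C)cnc3n2)c1`) gives 41.7 nM and compound 2 (`COc1cccc(-c2cc(O)c3c(C)ccnc3n2)c1`) gives 25.7 nM. Within the data shown here, compound 2 thus stands within the scatter of compound 1, the only other number available, and the two cannot be ranked.

The next compound to be tested is compound 3 (`COc1cccc(-c2cc(O)c3cccnc3n2)c1`), which is compound 2 with one small change: hydrogen in place of methyl on an aromatic carbon. This is hydrogen in place of methyl on an aromatic carbon, opposite the ring nitrogen. Among the measured compounds shown here, no measured pair in the set shows what such a change does, so there is no direct precedent for the size of the step. The expectation therefore rests on the two values in hand and is held loosely. A modest move toward a higher number is expected, close to the edge of the scatter, and the estimated change is a 1.9-fold higher number from compound 2 to compound 3 (0.29 log units; within the scatter) in this assay. For compound 3 the estimated value is 50 nM, with a range from 16 nM to 160 nM expected.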

Compound 3, concentration for 50% growth inhibition: 55 nM
For compound 3 the middle estimate is 1.1-fold (0.04 log units) below the measured one; the range from low to high includes it.
By their numbers in this assay, from the lowest: compounds 2, 1 and 3 (each within the scatter of the next, the first and the last beyond it).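

Hydrogen in place of methyl on the aromatic carbon opposite the ring nitrogen gives the first readable step at this position: in this assay the change produces a 2.1-fold higher number from compound 2 to compound 3 (0.33 log units; beyond the scatter) and so lies just beyond the scatter, a modest step that shows the methyl at this place counts for something in growth inhibition, though not for much. The same exchange at the methyl of compound 1, which sits at another place on the core, gives a 1.3-fold higher number from compound 1 to compound 3 (0.12 log units; within the scatter) and stays within the scatter, so at that place the methyl and hydrogen cannot be told apart. The two positions therefore do not read alike, although the margin is thin, since the step from compound 2 barely clears the scatter.

What the compounds shown leave open is whether anything other than methyl at the position opposite the ring nitrogen, such as an ethyl group, a methoxy group or an amine, would widen this step or reverse it. Whether the step holds on a core with a different aryl group also remains open, and nothing given here accounts for the step itself.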